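Chloro in place of methoxy on compound 1

The compounds below may be only part of what the source reports. "The series", "measured", "known", "first", "only" and "open" are said of these compounds alone.

- compound 1 `COc1ccc(-c2nsc3c2NC(=O)CC3c2cccc(OC)c2)cc1` at 3220 nM
- compound 2 `COc1ccc(-c2nsc3c2NC(=O)CC3c2ccc3c(c2)OCCO3)cc1` at 1410 nM

In a functional assay on OVCAR-8 cells (Homo sapiens) for antiproliferative activity, read by luminescence and CellTiter-Glo, with a stated time of 4 days (on this read-out higher numbers stand for weaker inhibition of growth and lower numbers for stronger inhibition of growth), compound 1 gives 3220 nM and stands highest of the two numbers, while compound 2 gives 1410 nM as the lower number, a gap beyond the usual scatter. Compound 3 `COc1ccc(-c2nsc3c2NC(=O)CC3c2cccc(Cl)c2)cc1` is still unmeasured. It carries chloro in place of methoxy on an aromatic carbon, meta to a large group (chloro in place of methoxy on an aromatic carbon). The same change reads as 3-methoxyphenyl to 3-chlorophenyl.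

For the measured compounds named here, the series holds no measured example of this exchange, so the expectation rests on thin ground. Going by the values given here, the only measured spread is compound 2 at 1410 nM against compound 1 at 3220 nM in the series so far, which points to a modest move at most. In this assay no step beyond the scatter is expected for this exchange, and any drift is expected to be toward a lower number. The expected step of a 1.3-fold lower number from compound 1 to compound 3 (0.11 log units; within the scatter) is small against the width of the estimated range. For compound 3 the estimate is 2500 nM with an expected range from 900 nM to 7000 nM on this thin evidence.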

Compound 3, concentration for 50% growth inhibition: 2920 nM
Estimate against measurement, compound 3: 1.2-fold (0.07 log units) below; the range from low to high includes it.
By their numbers in this assay, from the lowest: compound 2; then compounds 3 and 1 (each within the scatter of the next).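

Chloro in place of methoxy on an aromatic carbon, meta to a large group, gives in this assay a 1.1-fold lower number from compound 1 to compound 3 (0.04 log units; within the scatter) and thus provides the first measured example of this exchange in the series, with the two compounds not distinguishable in this read-out. At this position, the 2 heavy atoms of methoxy, with its 1 hydrogen-bond acceptor, give way to the 1 heavy atom of chloro, with no hydrogen-bond acceptor, and this difference in counts comes with no step beyond the scatter. No measurement at hand bears on what lies behind this result.

This single pair gives the behaviour of the exchange only for 3-methoxyphenyl and 3-chlorophenyl on the shared core, so it cannot be said whether the same result would hold with the exchange made elsewhere on the ring or on another compound of the series. Also open, on these data alone, is how this position responds to groups of a different kind, such as an amine, a carboxylic acid or a longer alkoxy chain, since methoxy and chloro alone span only a narrow set of substituents.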